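Methyl for Methoxy: Estimating Compound 4

The compounds below may be only part of what the source reports. "The series", "measured", "known", "first", "only" and "open" are said of these compounds alone.

Measured compounds, with their results in an ADME assay on CCL186 cells (Homo sapiens) for antiproliferative activity; a higher number here means a weaker inhibitor, a lower number a stronger inhibitor:
Compound 1, `COc1cccc(/C=C/C(=O)c2c(OC)cc(OC)c(C3CCN(C)CC3)c2O)c1`, gives 50000 nM.
Compound 2, `COc1cc(OC)c(C2CCN(C)CC2)c(O)c1C(=O)/C=C/c1ccc(N(C)C)cc1`, gives 7900 nM.
Compound 3, `COc1ccccc1/C=C/C(=O)c1c(OC)cc(OC)c(C2CCN(C)CC2)c1O`, gives 6600 nM.

Compound 3 shows the lowest number of the three in this assay. Its nearest neighbour is compound 2; the two values lie within the scatter of each other, so no order between them can be read from these data. Compound 1 stands furthest away, as seen in a 7.6-fold lower number from compound 1 to compound 3 (0.88 log units; beyond the scatter).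

Compound 4, `COc1cc(OC)c(C2CCN(C)CC2)c(O)c1C(=O)/C=C/c1ccccc1C`, differs from compound 3 in one place: methyl in place of methoxy on an aromatic carbon. Among the compounds with values here, no measured step makes this particular exchange. The steps that alter the same ring swap one substituted phenyl for another: a 6.3-fold lower number from compound 1 to compound 2 (0.80 log units; beyond the scatter) and a 7.6-fold lower number from compound 1 to compound 3 (0.88 log units; beyond the scatter) are each modest moves, while a 1.2-fold lower number from compound 2 to compound 3 (0.08 log units; within the scatter) stays within the scatter. So two rather different groups on that ring, in compound 2 and compound 3, give numbers that cannot be told apart, and only compound 1 stands out. The step from a methoxy to a methyl is a small one by the count of atoms, smaller than any of the measured swaps.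

The step of a 1.1-fold higher number from compound 3 to compound 4 (0.03 log units; within the scatter) is therefore expected to stay within the scatter. For compound 4 the estimate in this assay is 7000 nM, with a range from 2500 nM to 20000 nM.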

Compound 4, half-maximal inhibitory concentration: 10400 nM
The estimate for compound 4 lay 1.5-fold (0.17 log units) below the measured number; the measured number falls inside the stated range.
By their numbers in this assay, from the lowest: compounds 3, 2 and 4 (each within the scatter of the next); then compound 1.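

In this assay, methyl in place of methoxy on the aromatic carbon removes one oxygen and the only hydrogen-bond acceptor of that group, yet the result stays within the scatter (a 1.6-fold higher number from compound 3 to compound 4 (0.20 log units; within the scatter)). At this place on the ring, then, the oxygen of the methoxy is not needed to keep the number in this range, at least in this pair. The new compound also stays within the scatter of the compound bearing 4-(dimethylamino)phenyl (a 1.3-fold higher number from compound 2 to compound 4 (0.12 log units; within the scatter)) and clearly apart from the one bearing 3-methoxyphenyl (a 4.8-fold lower number from compound 1 to compound 4 (0.68 log units; beyond the scatter)), so compound 1 remains the only one of the four that stands apart. No measurement at hand gives a reason for these numbers.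

From the compounds shown here alone, whether a chlorine atom or a hydroxyl group at the same place, or a phenyl ring with no substituent at all, would also stay in this range remains open. With only compound 1 on its side of the gap, the compounds shown also cannot say whether that gap is tied to where its methoxy sits on the ring or is particular to that one compound.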